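Removing a methylamino group: one change, measured and expected

The source may report more compounds than this note shows. Statements on the series, on what has been measured and on what is new or still open speak of the compounds shown alone.

Three compounds have been measured in a functional assay on MIA PaCa-2 cells (Homo sapiens) for cytotoxicity, read by luminescence, with a stated time of 72 h, in the presence of a further agent that is not named here; on this read-out higher numbers stand for weaker inhibition and lower numbers for stronger inhibition:

compound 1, `CNc1c(F)ccc2c(C=NNC(=S)N(C)C)nccc12`, gives 38.4 nM
compound 2, `CN(C)C(=S)NN=Cc1nccc2cc(F)ccc12`, gives 21.6 nM
compound 3, `CNc1cccc2c(C=NNC(=S)N(C)C)ncc(F)c12`, gives 42.3 nM

Compound 1 and compound 2 differ in a single way, (hydrogen in place of methylamino on an aromatic carbon), and this change gave a 1.8-fold lower number from compound 1 to compound 2 (0.25 log units; within the scatter), so the two numbers cannot be told apart with confidence. Compound 3 has the same atoms as compound 1 joined differently; how the two cores differ is not broken down here. Compound 3 also stands close to both others, with all three numbers falling within the usual spread of repeated measurements.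

Compound 4, `CN(C)C(=S)NN=Cc1ncc(F)c2ccccc12`, has not yet been measured. It relates to compound 3 through (hydrogen in place of methylamino on an aromatic carbon). This is the same kind of change as that from compound 1 to compound 2, though not the same: in compound 1 the place was also ortho to a fluoro group, while in compound 3 it is not.

Because a 1.8-fold lower number from compound 1 to compound 2 (0.25 log units; within the scatter) was small, a step of similar size is expected for compound 4, namely a 1.6-fold lower number from compound 3 to compound 4 (0.21 log units; within the scatter). Compound 4 is therefore estimated to give 26 nM, with the value expected to fall between 12 nM and 55 nM.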

Compound 4, half-maximal inhibitory concentration: 26.6 nM
Estimate against measurement, compound 4: 1.0-fold (0.01 log units) below, within the range that was stated.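

In this assay, putting hydrogen in place of methylamino on the core of compound 3 gives a 1.6-fold lower number from compound 3 to compound 4 (0.20 log units; within the scatter), so the two numbers cannot be told apart with confidence. This shows that, on these two cores, the change moves the number by no more than repeated measurements of the same compound might, and that what was seen on one core also held on the other; it does not show that the change would stay this small on a third core, and two small steps say nothing about why it is small. Set side by side, the two steps agree: the same change on two cores in this assay, a 1.8-fold lower number (0.25 log units; within the scatter) from compound 1 to compound 2 and a 1.6-fold lower number (0.20 log units; within the scatter) from compound 3 to compound 4, 1.1-fold (0.05 log units) apart, within the scatter of two such steps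

The compounds shown leave open whether the same place would tolerate something larger or quite different, such as a longer chain like butylamino, or a carboxylic acid. They also leave open whether any group there could move the number beyond the usual scatter at all.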